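The source may hold more compounds than are shown below. What is called first, only, known or untested is meant among the compounds shown, and "the series" means these compounds.

Measured compounds:
- compound 1, `Nc1cc(N)c2nc(-c3ccccc3)c(NCc3ccc(Cl)c(Cl)c3)nc2c1`: 52500 nM
- compound 2, `CCOC(=O)[C@H](CCC(=O)O)NC(=O)c1ccc(Oc2nc3cc(N)cc(N)c3nc2-c2ccccc2)cc1`: < 100000 nM

For the measured compounds named here, in a functional assay on MDA-MB-435 cells (Homo sapiens) for inhibition, read by sulforhodamine B assay, with a stated time of 48 h (on this read-out lower numbers stand for higher toxicity in this test and higher numbers for lower toxicity in this test), compound 1 gives 52500 nM, the only actual number among the results so far. Compound 2 gives only a limit of the test, < 100000 nM, so its position cannot be ranked against anything else; this is the same limit noted in the limit of < 100000 nM in this assay, at which 1 of the 2 values shown sits. Compound 1 therefore stands alone as a weakly toxic reference point.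

Compound 3, `COc1ccc(CNc2nc3cc(N)cc(N)c3nc2-c2ccccc2)cc1`, is not yet measured. It differs from compound 1 by a single swap: 4-methoxyphenyl in place of 3,4-dichlorophenyl on a saturated chain carbon bound to a nitrogen on an aromatic ring. Going by the values given here, no measured pair in this set shows what such a swap does, so the expectation rests only on the starting value of compound 1 and the change itself. The step from compound 1 to compound 3 in this assay is expected to be small, toward lower toxicity, and possibly no larger than the scatter: a 1.5-fold higher number from compound 1 to compound 3 (0.18 log units; within the scatter). Compound 3 is estimated at 80000 nM, within 30000 nM to 200000 nM, and it may well return only a limit.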

Compound 3, concentration lethal to 50% of the cells: 46800 nM
Estimate against measurement, compound 3: 1.7-fold (0.23 log units) above; low and high end bracket the measured number.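

In this assay, for the compounds shown here, placing 4-methoxyphenyl in place of 3,4-dichlorophenyl on a saturated chain carbon bound to a nitrogen on an aromatic ring gives a 1.1-fold lower number from compound 1 to compound 3 (0.05 log units; within the scatter), the first step that can be read in this set. At this place, then, two differently substituted rings of the same size cannot be told apart in this test, even though the chlorine atoms leave and an oxygen enters. Nothing measured here explains why this swap makes no readable difference.

This single step cannot show whether the test responds to other groups at this place, such as a carboxylic acid, an amine or a longer chain. It also leaves open whether an unsubstituted phenyl ring would read the same as the two rings compared here.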